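Sulfonyl amine and chain length in an indoleamine 2,3-dioxygenase 1 series

This account rests on a few compounds, and the source may have more. Where it says the series, first, only, none or still open, it means among the compounds named here.

Measured so far in an assay on isolated protein for inhibition of Indoleamine 2,3-dioxygenase 1 (Homo sapiens), read by fluorescence, with a stated time of 60 min; a lower number here means a stronger inhibitor, a higher number a weaker inhibitor:
compound 1, `NS(=O)(=O)CCNc1nonc1/C(=N/O)Nc1ccc(F)c(Br)c1`, gives 71 nM.
compound 2, `CN(C)S(=O)(=O)CCNc1nonc1/C(=N/O)Nc1ccc(F)c(Br)c1`, gives 105 nM.
compound 3, `NS(=O)(=O)CCCNc1nonc1/C(=N/O)Nc1ccc(F)c(Br)c1`, gives 126 nM.

The three compounds share one core and differ only in the side chain carried on the nitrogen on the aromatic ring. Between compound 1 and compound 2 the change is dimethylamino in place of amino on a sulfonyl sulfur, and it gave a 1.5-fold higher number from compound 1 to compound 2 (0.17 log units; within the scatter). Compound 3 differs from compound 1 by sulfamoylmethyl in place of sulfamoyl on a saturated chain carbon, two bonds along the chain from a nitrogen on an aromatic ring, with a 1.8-fold higher number from compound 1 to compound 3 (0.25 log units; within the scatter); between compound 2 and compound 3 the record shows a 1.2-fold higher number from compound 2 to compound 3 (0.08 log units; within the scatter). All three numbers therefore sit within the usual scatter of one another, and none of the three can be set apart as stronger or weaker.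

Compound 4, `CN(C)S(=O)(=O)CCCNc1nonc1/C(=N/O)Nc1ccc(F)c(Br)c1`, has not yet been measured in this assay. It differs from compound 3 by dimethylamino in place of amino on a sulfonyl sulfur. The place is the same word for word as for the change from compound 1 to compound 2, so this is the same change applied on the longer chain of compound 3. Among the measured compounds shown here, the only guide to its size is that compound 1 to compound 2 gave a 1.5-fold higher number from compound 1 to compound 2 (0.17 log units; within the scatter), so the step from compound 3 to compound 4 is expected to be about a 1.4-fold higher number from compound 3 to compound 4 (0.15 log units; within the scatter). Whether the longer chain alters the effect cannot be told from one prior pair. Compound 4 is expected to come out at about 180 nM, between 95 nM and 340 nM.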

Compound 4, half-maximal inhibitory concentration: 97 nM
For compound 4 the middle estimate is 1.9-fold (0.27 log units) above the measured one; the range from low to high includes it.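

On the longer chain, dimethylamino in place of amino on a sulfonyl sulfur gave a 1.3-fold lower number from compound 3 to compound 4 (0.11 log units; within the scatter), and set against the same change on the shorter chain, the two steps do not differ: the same change on two cores in this assay, a 1.5-fold higher number (0.17 log units; within the scatter) from compound 1 to compound 2 and a 1.3-fold lower number (0.11 log units; within the scatter) from compound 3 to compound 4, 1.9-fold (0.28 log units) apart, within the scatter of two such steps. Among the compounds shown here, the other two new steps also stay small in this assay, with a 1.1-fold lower number from compound 2 to compound 4 (0.03 log units; within the scatter) for the longer chain with dimethylsulfamoyl at its end and a 1.4-fold higher number from compound 1 to compound 4 (0.14 log units; within the scatter) for the two changes taken together, so no compound of the four can be set apart from the others. The change therefore carries from one core to the other without a step beyond the scatter, but this does not show that it has an effect of its own on either core, and two pairs say nothing about cores other than these.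

Still open is whether a different amine on the sulfonyl sulfur, such as morpholine or a monomethylamino group, or a longer chain than those shown would give a step beyond the scatter. Also open, as far as these compounds go, is whether the same change stays this small when the bromine or fluorine on the aromatic ring is replaced by another group, such as chlorine or a nitrile.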